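This account rests on a few compounds, and the source may have more. Where it says the series, first, only, none or still open, it means among the compounds named here.

In a toxicity assay on MT4 cells (Homo sapiens) for cytotoxicity, read by MTT assay, with a stated time of 5 days (on this read-out higher numbers stand for lower toxicity in this test and lower numbers for higher toxicity in this test), compound 1 `Cc1cc(-c2ccco2)cc(C)c1Nc1ccnc(Nc2ccc(C#N)cc2)n1` gives 1700 nM, compound 2 `Cc1cc(-c2cc3ccccc3s2)cc(C)c1Nc1ccnc(Nc2ccc(C#N)cc2)n1` gives 138000 nM, and compound 3 `Cc1cc(-c2ccnc(F)c2)cc(C)c1Nc1ccnc(Nc2ccc(C#N)cc2)n1` gives 6000 nM. These compounds share a core and differ in one group, so compound 3 holds the middle place of the three, closer to compound 1 than to compound 2.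

Compound 4 `COc1ncc(-c2cc(C)c(Nc3ccnc(Nc4ccc(C#N)cc4)n3)c(C)c2)cn1` has not yet been measured. It differs from compound 3 at that same place: 2-methoxypyrimidin-5-yl stands in place of 2-fluoropyridin-4-yl on an aromatic carbon (2-methoxypyrimidin-5-yl in place of 2-fluoropyridin-4-yl on an aromatic carbon). Both groups hold one six-membered aromatic ring, and the new group has more hetero atoms.

Among the measured compounds shown here, no measured step makes this exact swap, so the evidence is indirect. The two large steps, an 81-fold higher number from compound 1 to compound 2 (1.91 log units; beyond the scatter) and a 23-fold lower number from compound 2 to compound 3 (1.36 log units; beyond the scatter), both involve the 1-benzothiophen-2-yl group of compound 2, which does not take part in this swap. The modest 3.5-fold higher number from compound 1 to compound 3 (0.55 log units; beyond the scatter), between furan-2-yl and 2-fluoropyridin-4-yl, is the better guide to the size of change.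

A small step with no firm direction is therefore expected, and it may not clear the usual scatter. The expected step is a 1.2-fold higher number from compound 3 to compound 4 (0.07 log units; within the scatter). The estimated value for compound 4 is 7000 nM, with an expected range from 2500 nM to 30000 nM.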

Compound 4, half-maximal cytotoxic concentration: 4800 nM
The estimate for compound 4 lay 1.5-fold (0.16 log units) above the measured number; the measured number falls inside the stated range.
By their numbers in this assay, from the lowest: compound 1; then compounds 4 and 3 (each within the scatter of the next); then compound 2.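

In this assay, replacing 2-fluoropyridin-4-yl with 2-methoxypyrimidin-5-yl gives a 1.3-fold lower number from compound 3 to compound 4 (0.10 log units; within the scatter), so at this place on the ring, meta to the two methyl groups, a second group built on one six-membered aromatic ring reads alike despite its different hetero atoms and its methoxy in place of fluorine. The new group also repeats the position of 2-fluoropyridin-4-yl relative to the two other groups, with a 2.8-fold higher number from compound 1 to compound 4 (0.45 log units; beyond the scatter) against furan-2-yl and a 29-fold lower number from compound 2 to compound 4 (1.46 log units; beyond the scatter) against 1-benzothiophen-2-yl, so both six-membered-ring compounds lie on the same side of each of these compounds. Nothing measured alongside these numbers accounts for them, so the likeness of compound 3 and compound 4 stays a description and not an explanation.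

Every group shown at this place is aromatic, so how an amine or a carboxylic acid would read here remains open. From the compounds shown here alone, it also remains open whether the high number of compound 2 belongs to the 1-benzothiophen-2-yl group alone or would return with other large groups.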